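Methyl on the aromatic carbon: cytotoxicity notes

A few compounds are considered here, and "the series" means these few. Any claim that something is new, unique, unknown or untested is made for them only; others in the source may bear on it.

Compound 1 `O=C(CCCCC1CCSS1)NCc1cn(CCCOc2ccc3ccc(=O)oc3c2)nn1` and compound 2 `Cc1cc(=O)oc2cc(OCCCn3cc(CNC(=O)CCCCC4CCSS4)nn3)ccc12` share one core and differ only by methyl in place of hydrogen on an aromatic carbon. In a functional assay on PC-12 cells (Rattus norvegicus) for cytotoxicity, read by MTT assay, with stated times of 3 h and 2 h, tested at 50 uM (on this read-out higher numbers stand for a stronger effect at the one concentration tested and lower numbers for a weaker effect), compound 1 gives 43.5%, and compound 2 gives 75.4%; the step between them is a number 31.9 percentage points higher from compound 1 to compound 2 (beyond the scatter). Compound 3 `O=C(CCCCC1CCSS1)NCc1cn(CCCCCOc2ccc3ccc(=O)oc3c2)nn1` carries a longer chain; the difference between the cores of compound 1 and compound 3 is not broken down here. In this assay compound 3 gives 84.9%; its gap to compound 2 lies within the scatter, its gap to compound 1 beyond it. Compound 4 `Cc1cc(=O)oc2cc(OCCCCCn3cc(CNC(=O)CCCCC4CCSS4)nn3)ccc12` has not yet been measured. It differs from compound 3 by methyl in place of hydrogen on an aromatic carbon, the same change as from compound 1 to compound 2, at the same place; among the four compounds this change occurs twice. For compound 4 a step of a number 5.1 percentage points higher from compound 3 to compound 4 (within the scatter) is expected in this assay, smaller than the earlier step, because compound 3 already stands at 84.9% and a percentage read-out has little room above that. Compound 4 is estimated at 90%, with a range from 75% to 100%.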

Compound 4, a percentage reported as activity, at one concentration (the size of the read-out at that concentration, not a potency): 73.7%
Estimate against measurement, compound 4: 16.3 percentage points above; measured number outside the range, below it.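

In this assay, methyl in place of hydrogen on an aromatic carbon gives a number 11.2 percentage points lower from compound 3 to compound 4 (beyond the scatter), a weaker effect at the one concentration tested. The change does not carry over from the core of compound 1 to the core of compound 3 with the same direction or size: the same change on two cores in this assay, a number 31.9 percentage points higher (beyond the scatter) from compound 1 to compound 2 and a number 11.2 percentage points lower (beyond the scatter) from compound 3 to compound 4, 43.1 percentage points apart, beyond the scatter of two such steps This shows that the step on one core cannot be used to predict the step on the other in this series, but two pairs do not show why the steps part, and single-concentration read-outs say nothing about potency.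

The compounds shown leave open how the methyl step behaves with a longer chain than that of compound 3, and so whether the reversal continues or is confined to these two cores. They also leave open whether an ethyl group or a chlorine atom, opposite the ring oxygen, would follow methyl on either core.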